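A few compounds are considered here, and "the series" means these few. Any claim that something is new, unique, unknown or untested is made for them only; others in the source may bear on it.

Compound 1 `CN1CCN(CCCNc2nc(-c3ccccn3)nc3c2CN(Cc2ccccc2)CC3)CC1` and compound 2 `CN(C)CCN1CCN(c2nc(-c3ccccn3)nc3c2CN(Cc2ccccc2)CC3)CC1` share a core and differ in one group. In an assay on FRT cells with Cystic fibrosis transmembrane conductance regulator variant F508del (Homo sapiens) as the target, read by fluorescence, with a stated time of 25 min (on this read-out higher numbers stand for larger maximal responses and lower numbers for smaller maximal responses), compound 1 reaches 53.4%, while compound 2 reaches 41.3% in this assay. The change between them is 4-(2-(dimethylamino)ethyl)piperazin-1-yl in place of (3-(4-methylpiperazin-1-yl)propyl)amino on an aromatic carbon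

and the step it made was a number 12.1 percentage points lower from compound 1 to compound 2 (beyond the scatter), a drop beyond the usual scatter.

Compound 3 `CN1CCN(CCCNc2nc(-c3cccnc3)nc3c2CN(Cc2ccccc2)CC3)CC1` carries the same side chain as compound 1 but a different core; the difference between the two cores is pyridin-3-yl in place of pyridin-2-yl on an aromatic carbon

In this assay compound 3 is reported as "not active" (no number reported), with no number given.

Compound 4 `CN(C)CCN1CCN(c2nc(-c3cccnc3)nc3c2CN(Cc2ccccc2)CC3)CC1` is not yet measured. It stands to compound 3 as compound 2 stands to compound 1: the change is 4-(2-(dimethylamino)ethyl)piperazin-1-yl in place of (3-(4-methylpiperazin-1-yl)propyl)amino on an aromatic carbon

The two surroundings differ only in that the place is meta to a pyridin-3-yl group in compound 3 and compound 4, where it is meta to a pyridin-2-yl group in compound 1 and compound 2, so this is the same kind of change rather than the same change.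

Given that the same kind of change lowered the maximal response in the step of a number 12.1 percentage points lower from compound 1 to compound 2 (beyond the scatter), and that compound 3 itself produced no measurable response in this assay, compound 4 is expected to show little or no maximal response as well. The estimate for compound 4 in this assay is 8%, with an expected range from 0% to 30%, and it is likely that the assay again reports it as not active.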

Compound 4, largest response reached (Emax), in percent of the reference or control that the assay uses: "not active" (no number reported)
Nothing numeric was reported for compound 4, so the estimate cannot be set against anything.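

In this assay compound 3 and compound 4 are both reported without a number, so no step can be read between them. The compounds shown leave open whether the change of side chain has any effect on the maximal response when pyridin-3-yl stands in place of pyridin-2-yl. No measured evidence shown here bears on this result.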